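Replacing a fluorophenyl by a naphthyl in a lipophilicity series

The compounds below may be only part of what the source reports. "The series", "measured", "known", "first", "only" and "open" are said of these compounds alone.

Of the compounds shown here, three of one series have been measured in a physicochemical assay for lipophilicity; on this read-out higher numbers stand for higher lipophilicity and lower numbers for lower lipophilicity. Compound 1 `N=C(N)Nc1cccc(C(=O)NNC(=O)CC(CC(=O)O)c2ccc(Cl)cc2)c1` gives 1.68 in this assay, and compound 2 `N=C(N)Nc1cccc(C(=O)NNC(=O)CC(CC(=O)O)c2cc(Cl)cc(Cl)c2)c1` gives 2.24. Among the compounds with values here, the step of a number 0.56 log units higher from compound 1 to compound 2 (beyond the scatter) is the only single change among the measured compounds. Compound 3 `N=C(N)Nc1cccc(C(=O)NNC(=O)NC(CC(=O)O)c2ccc(F)cc2)c1` gives 0.86 in this assay, the lowest of the three numbers, with compound 1 nearest and compound 2 furthest.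

Compound 4 `N=C(N)Nc1cccc(C(=O)NNC(=O)NC(CC(=O)O)c2cccc3ccccc23)c1` is not yet measured. Compared with compound 3, the change is naphthalen-1-yl in place of 4-fluorophenyl on a saturated chain carbon bound to an amide-type nitrogen and a saturated chain carbon. Within the data shown here, no measured step concerns this exchange; the step from compound 1 to compound 2 only bears on it as a reference for how much a larger aryl group raised this assay, and that exchange added fewer heavy atoms than this one does. A rise beyond the scatter is therefore expected for compound 4, of the size a number 1.04 log units higher from compound 3 to compound 4 (beyond the scatter). Compound 4 is estimated at 1.9 in this assay, within 1.4 to 2.4.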

Compound 4, partition coefficient: 1.7
Beside the measured number, compound 4's estimate is 0.20 log units above it; the measured number falls inside the stated range.
By their numbers in this assay, from the lowest: compound 3; then compounds 1 and 4 (each within the scatter of the next); then compound 2.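

With naphthalen-1-yl in place of 4-fluorophenyl on a saturated chain carbon bound to an amide-type nitrogen and a saturated chain carbon, this assay shows a number 0.84 log units higher from compound 3 to compound 4 (beyond the scatter) for this exchange, so the number does respond to the aryl group at this place. Within the data shown here, the only earlier step, a number 0.56 log units higher from compound 1 to compound 2 (beyond the scatter) in the same assay, lay on a saturated chain carbon bound to two saturated chain carbons and said nothing directly about this position. Here the group that enters holds more heavy atoms than the group that leaves, with one six-membered aromatic ring of carbon only giving way to 2 such rings.

Going by these compounds, whether an unsubstituted phenyl or a naphthalen-2-yl at this place would give a similar number remains open. No evidence at hand accounts for the size of this step.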